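This account rests on a few compounds, and the source may have more. Where it says the series, first, only, none or still open, it means among the compounds named here.

The shared core of compound 1, `CCC/N=C(\NC#N)Nc1cccnc1`, carries a propyl group on a double-bonded nitrogen. In a functional assay on the whole organism (blood, strain Wistar-Okamoto) with Rattus norvegicus as the target, with a stated time of 5 days (on this read-out higher numbers stand for an effect only at larger amounts of compound and lower numbers for an effect already at smaller amounts), compound 1 gives 20 mg/kg, the highest of the two numbers that have been measured. Its nearest neighbour is compound 2, `CC(/N=C(/NC#N)Nc1cccnc1)C(C)(C)C`, which in this assay gives 1 mg/kg, a step that lies well beyond the scatter of repeated measurements.

Compound 3, `CCCC(C)(C)/N=C(\NC#N)Nc1cccnc1`, is the next compound to be examined in this assay and has not yet been measured. It differs from compound 1 in one place: 1,1-dimethylbutyl in place of propyl on a double-bonded nitrogen. Among the measured compounds shown here, no directly comparable step between measured compounds is available for this change, so what its size might be can only be inferred from the two values shown.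

Because compound 2 gives 1 mg/kg in this assay, a move away from the propyl group of compound 1 is expected to bring a lower number, though with an uncertain size. Compound 3 is therefore estimated to give 3 mg/kg, with a range from 1 mg/kg to 10 mg/kg. The expected step of a 6.7-fold lower number from compound 1 to compound 3 (0.82 log units; beyond the scatter) would lie beyond the scatter.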

Compound 3, minimum effective dose: 1 mg/kg
Beside the measured number, compound 3's estimate is 3.0-fold (0.48 log units) above it; low and high end bracket the measured number.
By their numbers in this assay, from the lowest: compounds 2 and 3 (each within the scatter of the next); then compound 1.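

In this assay, among the compounds shown here, replacing propyl with 1,1-dimethylbutyl on a double-bonded nitrogen gives a 20-fold lower number from compound 1 to compound 3 (1.30 log units; beyond the scatter), the first step read between compounds that differ in one place, and it shows that this position can take a group of 6 carbon atoms in place of one of 3 with a large gain on this read-out. Compound 2 gives 1 mg/kg and compound 3 gives 1 mg/kg, two values within the scatter of each other, so two different groups at this place now stand at the same level, and both are well apart from propyl in compound 1. Nothing available here accounts for the size of this step, which therefore stands as an observation about these three compounds alone.

The compounds shown leave open whether the step follows from the number of carbon atoms in the group or from how those atoms are arranged, which a straight hexyl chain or a cyclohexyl ring at the same place would help to separate. They also leave open whether a group carrying an amine or a hydroxyl at this position would keep a number as low as that of compound 3.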